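The source may hold more compounds than are shown below. What is called first, only, known or untested is meant among the compounds shown, and "the series" means these compounds.

Two compounds here share one core and differ only in what sits on a nitrogen attached to an aromatic ring. Compound 1 `CN(C)CCN(CCN(C)C)c1ccc(C(=O)N2CCc3ccc(OS(N)(=O)=O)cc3C2)cc1` gives 3.8% in an assay on HEK293 cells for inhibition of Steryl-sulfatase (Homo sapiens), tested at 0.1 uM; a lower number here means a weaker effect, a higher number a stronger effect of the compound at the concentration tested. Among the measured compounds shown here, compound 2 `CCCN(CCC)c1ccc(C(=O)N2CCc3ccc(OS(N)(=O)=O)cc3C2)cc1` gives 36.6% in this assay, the higher of the two numbers seen so far; its only neighbour is compound 1, and the change between them is a number 32.8 percentage points higher from compound 1 to compound 2 (beyond the scatter). Compound 3 `CCCN(Cc1ccccc1)c1ccc(C(=O)N2CCc3ccc(OS(N)(=O)=O)cc3C2)cc1` has not yet been measured. It differs from compound 2 by phenyl in place of ethyl on a saturated chain carbon bound to a nitrogen on an aromatic ring. For the measured compounds named here, the one measured step exchanged the whole group on that nitrogen, not a single arm of it, so it bears only loosely on the change to compound 3 and gives no direct guide to its size or direction. Compound 3 is therefore expected to give about 40%, within 15% to 65%, an expected step of a number 3.4 percentage points higher from compound 2 to compound 3 (within the scatter) that likely stays within the usual scatter.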

Compound 3, a percentage reported as inhibition, at one concentration (the size of the read-out at that concentration, not a potency): 64.8%
For compound 3 the middle estimate is 24.8 percentage points below the measured one; the measured number falls inside the stated range.
By their numbers in this assay, from the lowest: compound 1; then compound 2; then compound 3.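

In this assay, exchanging a single arm on the nitrogen, propyl to benzyl, gives a number 28.2 percentage points higher from compound 2 to compound 3 (beyond the scatter) and so shows that this position responds to a change in one arm, not only to replacement of the whole group. Across the whole group, benzyl(propyl)amino in place of bis(2-(dimethylamino)ethyl)amino gives a number 61 percentage points higher from compound 1 to compound 3 (beyond the scatter) and this is the widest gap among the three compounds. Nothing available explains why the arm carrying the phenyl ring goes with the higher number.

As far as these compounds go, it remains open whether the aromatic ring itself matters or whether a saturated arm of similar size, such as cyclohexylmethyl or a longer chain like hexyl, would do the same. Also open, from the compounds shown here alone, is how the number would move with dibenzylamino on the nitrogen, or with a fluorine or methoxy group on the phenyl ring.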